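The source may hold more compounds than are shown below. What is called first, only, known or untested is meant among the compounds shown, and "the series" means these compounds.

Compound 1 `Cc1ccc(S(=O)(=O)NC(=O)Nc2ccccc2C(=O)/C=C/c2ccccc2)cc1`: 25 ug/mL
Compound 2 `COc1ccc(/C=C/C(=O)c2ccccc2NC(=O)NS(=O)(=O)c2ccc(C)cc2)cc1`: 28.1 ug/mL
Compound 3 `COc1ccc(/C=C/C(=O)c2ccccc2NC(=O)NS(=O)(=O)c2ccc(C)cc2)cc1OC`: 12.9 ug/mL

All three were measured in an ADME assay on the whole organism for cytotoxicity, with Artemia salina as the target, with a stated time of 24 h; on this read-out lower numbers stand for an effect already at smaller amounts and higher numbers for an effect only at larger amounts of compound. Compound 1 gives 25 ug/mL, the second highest of the three numbers. Its nearest neighbour on this read-out is compound 2, which gives 28.1 ug/mL; the most distant is compound 3, which gives 12.9 ug/mL. The steps between them are a 1.1-fold higher number from compound 1 to compound 2 (0.05 log units; within the scatter), a 2.2-fold lower number from compound 2 to compound 3 (0.34 log units; beyond the scatter) and a 1.9-fold lower number from compound 1 to compound 3 (0.29 log units; within the scatter).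

Compound 4 `Cc1ccc(S(=O)(=O)NC(=O)Nc2ccccc2C(=O)/C=C/c2cccc(O)c2)cc1` has not yet been measured. It differs from compound 1 in a single place: hydroxy in place of hydrogen on an aromatic carbon. Among the measured compounds shown here, none of the measured steps adds a hydroxy group, so the closest guides are the methoxy additions on the same aromatic ring. Those moved the number little: one step within the scatter, one just beyond it toward a lower number, and the two together again within the scatter. On that basis the expected step for compound 4 is a 1.3-fold lower number from compound 1 to compound 4 (0.10 log units; within the scatter), a change that should stay within the scatter or at most reach a modest lower number. The estimate for compound 4 in this assay is 20 ug/mL, with a range from 10 ug/mL to 40 ug/mL.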

Compound 4, concentration for half-maximal effect: 39.3 ug/mL
For compound 4 the middle estimate is 2.0-fold (0.29 log units) below the measured one, and the stated range covers the measured number.
By their numbers in this assay, from the lowest: compounds 3, 1, 2 and 4 (each within the scatter of the next, the first and the last beyond it).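

In this assay, adding hydroxy on an aromatic carbon, meta to a large group, is the first change shown that places a hydrogen-bond donor on this ring, and the step stays within the scatter (a 1.6-fold higher number from compound 1 to compound 4 (0.20 log units; within the scatter)). Compound 4 also stays within the scatter of the 4-methoxyphenyl compound (a 1.4-fold higher number from compound 2 to compound 4 (0.15 log units; within the scatter)), but it separates, modestly and beyond the scatter, from the 3,4-dimethoxyphenyl compound (a 3.0-fold higher number from compound 3 to compound 4 (0.48 log units; beyond the scatter)), so among these four compounds only that dimethoxy pattern sets a compound apart from the hydroxy compound. Nothing in the material shown accounts for these numbers or says what the hydroxy group does in the organism.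

A single hydroxy compound cannot show whether the oxygen matters here or whether almost any small group would give a similar number, so a 3-methoxyphenyl, 3-aminophenyl or 3-carboxyphenyl group in the same place would be the informative comparison. Among the compounds shown here, it also remains open whether this ring tolerates hydroxy together with a second group, as in a compound carrying both hydroxy and methoxy, since the one clear step in this set involves the two methoxy groups.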